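Replacing nitro with methyl on a weakly cytotoxic pyrazoline series

The source may hold more compounds than are shown below. What is called first, only, known or untested is meant among the compounds shown, and "the series" means these compounds.

Measured compounds:
compound 1 `CC1=NN(C(=O)/C=C/c2ccccc2)C(c2ccccc2O)C1` with 42000 nM
compound 2 `CC1=NN(C(=O)c2ccc([N+](=O)[O-])cc2)C(c2ccccc2O)C1` with 36600 nM

In a functional assay on PC-3 cells (Homo sapiens) for cytotoxicity, read by MTT assay, with a stated time of 48 h (on this read-out lower numbers stand for stronger inhibition and higher numbers for weaker inhibition), compound 2 gives 36600 nM, and compound 1 gives 42000 nM; the gap between the two lies within the scatter, so neither can be told apart from the other. Compound 3 `CC1=NN(C(=O)c2ccc(C)cc2)C(c2ccccc2O)C1` differs from compound 2 only in methyl in place of nitro on an aromatic carbon. No step between measured compounds has been shown, so the size of this change is unknown; the two measured numbers suggest the shared core sits in a weak range whatever the group. The step from compound 2 to compound 3 is expected to be a 1.1-fold higher number from compound 2 to compound 3 (0.04 log units; within the scatter), within the scatter. Compound 3 is therefore estimated at 40000 nM, with a range from 15000 nM to 100000 nM.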

Compound 3, half-maximal inhibitory concentration: 40600 nM
For compound 3 the middle estimate is 1.0-fold (0.01 log units) below the measured one; the range from low to high includes it.
By their numbers in this assay, from the lowest: compounds 2, 3 and 1 (each within the scatter of the next).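

In this assay this position now has a measured step, a 1.1-fold higher number from compound 2 to compound 3 (0.05 log units; within the scatter), and it shows that compound 2 and compound 3 cannot be told apart. Nitro and methyl, on an aromatic carbon para to a large group, thus give numbers within the scatter of each other, which the earlier compounds, differing in more than one place, could not show. Nothing measured bears on why this is so. Still open, going by these compounds, is whether an amine or a carboxylic acid at this place would give a number beyond the scatter.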